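Cytotoxicity notes on the amine substituent of the shared core

A few compounds are considered here, and "the series" means these few. Any claim that something is new, unique, unknown or untested is made for them only; others in the source may bear on it.

Measured so far:
Compound 1, `CCN(c1ccnc(Nc2ccc(C#N)cc2)n1)c1c(F)cc(-c2ccc(C#N)cc2)cc1F`, in an ADME assay on MT4 cells (Homo sapiens) for cytotoxicity, read by MTT assay, with a stated time of 5 days; a lower number here means that less compound is tolerated, a higher number that more compound is tolerated: 105000 nM
Compound 2, `N#Cc1ccc(Nc2nccc(N(c3c(F)cc(-c4ccc(C#N)cc4)cc3F)C3CCCC3)n2)cc1`, in this assay: 232000 nM
Compound 3, `CC(O)CN(c1ccnc(Nc2ccc(C#N)cc2)n1)c1c(F)cc(-c2ccc(C#N)cc2)cc1F`, in this assay: 9800 nM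

Compound 3 stands at the lowest number of the three, that is, it is the least tolerated. Its neighbours both lie beyond the scatter: an 11-fold lower number from compound 1 to compound 3 (1.03 log units; beyond the scatter) and a 24-fold lower number from compound 2 to compound 3 (1.37 log units; beyond the scatter). The two alkyl compounds differ from each other only modestly, a 2.2-fold higher number from compound 1 to compound 2 (0.34 log units; beyond the scatter).

Compound 4, `COCN(c1ccnc(Nc2ccc(C#N)cc2)n1)c1c(F)cc(-c2ccc(C#N)cc2)cc1F`, differs from compound 3 in one place: methoxy in place of 1-hydroxyethyl on a saturated chain carbon bound to a nitrogen on an aromatic ring. The hydrogen-bond donor that compound 3 alone carries is thus removed, while an oxygen acceptor stays on the chain. Among the measured compounds shown here, the steps that bear on this change are the two that lead to compound 3, an 11-fold lower number from compound 1 to compound 3 (1.03 log units; beyond the scatter) and a 24-fold lower number from compound 2 to compound 3 (1.37 log units; beyond the scatter), each large and each a move downward on entering the hydroxyl. Going the other way, toward a donor-free chain, a large step upward in this assay is expected for compound 4, a 5.1-fold higher number from compound 3 to compound 4 (0.71 log units; beyond the scatter), though no measured compound carries a methoxy on this chain, so the size is uncertain. Compound 4 is estimated at 50000 nM, with a range from 15000 nM to 200000 nM.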

Compound 4, half-maximal cytotoxic concentration: 238000 nM
The estimate for compound 4 lay 4.8-fold (0.68 log units) below the measured number; measured number outside the range, above it.
By their numbers in this assay, from the lowest: compound 3; then compound 1; then compounds 2 and 4 (each within the scatter of the next).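

Compound 4 keeps an oxygen acceptor on the chain, yet in this assay the change from 2-hydroxypropyl to methoxymethyl gives a 24-fold higher number from compound 3 to compound 4 (1.39 log units; beyond the scatter) and so separates the low number from the mere presence of oxygen at this position. Set against the alkyl substituents, the methoxymethyl chain shows a 1.0-fold higher number from compound 2 to compound 4 (0.01 log units; within the scatter) and a 2.3-fold higher number from compound 1 to compound 4 (0.36 log units; beyond the scatter), the first a match to cyclopentyl and the second a modest rise over ethyl. Of the four compounds, only compound 3 carries a hydrogen-bond donor on this chain and only compound 3 sits at the low end, a link that rests on that single compound.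

The change from 2-hydroxypropyl to methoxymethyl alters the chain as well as removing the hydroxyl, so it would take a 2-methoxypropyl group, or an amine in place of the hydroxyl on the same chain, to tell these two apart. Nothing available gives a measured reason for the difference between compound 3 and the other three compounds.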